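Chlorines for Methyls on the Thiophene of a Growth Inhibitor

The compounds below may be only part of what the source reports. "The series", "measured", "known", "first", "only" and "open" are said of these compounds alone.

Compound 1 `Cc1cc(-c2nc3n(c2/C=N/NC(=N)N)CCS3)c(C)s1` was tested in a functional assay on cells (Cancer cell lines, Homo sapiens) for inhibition (on this read-out lower numbers stand for stronger inhibition of growth and higher numbers for weaker inhibition of growth), where compound 1 gives 47900 nM. That is the higher of the two numbers recorded, yet the only comparator, compound 2 `Cc1cn2c(/C=N/Nc3ccccn3)c(-c3ccc(Cl)c([N+](=O)[O-])c3)nc2s1`, with 25700 nM, lies within the usual scatter, so the two cannot be ordered. Compound 3 `N=C(N)N/N=C/c1c(-c2cc(Cl)sc2Cl)nc2n1CCS2` awaits measurement; it differs from compound 1 by 2,5-dichlorothiophen-3-yl in place of 2,5-dimethylthiophen-3-yl on an aromatic carbon. Among the measured compounds shown here, no measured step covers a change of this kind, so the expected step is small, in either direction and likely no larger than the scatter, and the estimated step of a 1.5-fold lower number from compound 1 to compound 3 (0.18 log units; within the scatter) reflects that. Compound 3 is accordingly expected to give about 32000 nM, within a range from 9000 nM to 110000 nM.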

Compound 3, concentration for total growth inhibition: 22900 nM
Compound 3: the middle estimate sits 1.4-fold (0.15 log units) above what was measured; the measured number falls inside the stated range.
By their numbers in this assay, from the lowest: compounds 3, 2 and 1 (each within the scatter of the next, the first and the last beyond it).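

Among the compounds shown here, the exchange of 2,5-dimethylthiophen-3-yl for 2,5-dichlorothiophen-3-yl gives a 2.1-fold lower number from compound 1 to compound 3 (0.32 log units; beyond the scatter) in this assay and is the first single change read at this aromatic carbon. It shows that the thiophene substituents can be exchanged here with a modest gain in growth inhibition, although the number remains in the same range as the other two compounds. The compounds shown leave open whether one chlorine alone would give this step, and how an amine, a carboxylic acid or a longer alkyl chain on the thiophene would read out. No measurement offered here accounts for the step.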